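Cytotoxicity of a proline-derived peptide series: the isobutyl amide

This account rests on a few compounds, and the source may have more. Where it says the series, first, only, none or still open, it means among the compounds named here.

Measured compounds:
compound 1, `C[C@H](NC(=O)[C@@]1(Cc2ccccc2)CCN1C(=O)OCc1ccccc1)C(=O)NC(C)(C)C`, in an ADME assay on HELF cells (Homo sapiens) for cytotoxicity, with a stated time of 3 days (a higher number here means that more compound is tolerated, a lower number that less compound is tolerated), gives > 100000 nM, which is a limit of the assay;
compound 2, `C[C@H](NC(=O)[C@@]1(Cc2ccccc2)CCN1C(=O)OCc1ccccc1)C(=O)NCc1ccccc1`, in this assay gives >= 20000 nM, which is a limit of the assay;
compound 3, `CC(C)C[C@H](NC(=O)[C@@]1(Cc2ccccc2)CCN1C(=O)OCc1ccccc1)C(N)=O`, in this assay gives > 100000 nM, which is a limit of the assay.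

Compound 3 therefore stands at a limit rather than at a number in this assay, and the other two values shown are limits as well. The step from compound 1 to compound 3 reads a step that the two limits leave unreadable from compound 1 to compound 3, and the step from compound 2 to compound 3 reads a step that the two limits leave unreadable from compound 2 to compound 3; neither gives a readable size.

Compound 4, `CC(C)CNC(=O)[C@H](C)NC(=O)[C@@]1(Cc2ccccc2)CCN1C(=O)OCc1ccccc1`, has not yet been measured. It differs from compound 3 as follows: 1-(isobutylcarbamoyl)ethyl in place of 1-carbamoyl-3-methylbutyl on an amide-type nitrogen. Within the data shown here, the steps that bear on this change leave no size to carry over. Among the measured compounds shown here, what the three values do show is the limit of > 100000 nM in this assay, at which 2 of the 3 values shown sit, and (the limit of >= 20000 nM in this assay, at which 1 of the 3 values shown sits), so no compound has yet reached a measurable cytotoxic concentration in this assay.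

For compound 4 the step is expected to be a number no higher from compound 3 to compound 4 (the limit leaves the size open), that is, no change beyond the scatter. Compound 4 is therefore estimated at 100000 nM in this assay, with a range from 30000 nM to 300000 nM, and most likely the assay will again report only a limit.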

Compound 4, minimum cytotoxic concentration: > 100000 nM
Compound 4 gave a limit, no number (the forecaster's own chance of this, stated with the estimate: 80%); the middle value sits exactly at the limit.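

In this assay compound 4 gives > 100000 nM as a limit of the assay. No new step can be read from this result: the steps to compound 4 from compound 1, compound 2 and compound 3 all join limits and have no readable size. The compounds shown leave open at what concentration, if any, each of them becomes cytotoxic.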